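The source may report more compounds than this note shows. Statements on the series, on what has been measured and on what is new or still open speak of the compounds shown alone.

Measured so far:
Compound 1, `O=C(Nc1cccc(-n2cc(-c3ccncc3)c(-c3ccc(Cl)c(O)c3)n2)c1)Nc1ccc(Cl)c(Cl)c1`: 29600 nM
Compound 2, `COc1cc(-c2nn(-c3cccc(NC(=O)c4ccc(Cl)c(C(F)(F)F)c4)c3)cc2-c2ccncc2)ccc1Cl`: > 32500 nM

In a functional assay on HCT-15 cells (Homo sapiens) for inhibition, read by sulforhodamine B assay, with a stated time of 48 h (a higher number here means a weaker inhibitor of growth, a lower number a stronger inhibitor of growth), compound 1 gives 29600 nM. Compound 2, in this assay, gives only a limit of the assay and not a number: > 32500 nM. Compound 2 therefore stands at the edge of what this assay can report, as the limit of > 32500 nM in this assay, at which 1 of the 2 values shown sits, records. For the measured compounds named here, since one value is a number and the other a limit, the two compounds can only be set side by side; no step between them is computed here.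

Compound 3, `COc1cc(-c2nn(-c3cccc(NC(=O)c4cccc(C(F)(F)F)c4)c3)cc2-c2ccncc2)ccc1Cl`, has not yet been measured. It differs from compound 2 in one place: hydrogen in place of chloro on an aromatic carbon. Going by the values given here, because compound 2 gives only the limit > 32500 nM, there is no firm number to step from, and a small change such as the loss of one chloro gives no ground to expect a move beyond the usual scatter. The expected step is an at least 1.0-fold lower number from compound 2 to compound 3 (0.03 log units; that floor lies within the scatter), in effect none that the assay would resolve. Compound 3 is thus estimated at 30000 nM, with a range from 10000 nM to 60000 nM.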

Compound 3, concentration for total growth inhibition: > 50000 nM
Compound 3 was reported as a limit; the forecaster's own chance of this, stated with the estimate: 60%; at least 1.6-fold (0.22 log units) between middle value and limit.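

In this assay compound 2 gives > 32500 nM as a limit and not a number. Compound 3 likewise gives > 50000 nM as a limit and not a number. Two limits leave the step between compound 2 and compound 3 unreadable. Going by these compounds, whether going from 4-chloro-3-(trifluoromethyl)phenyl to 3-(trifluoromethyl)phenyl changes growth inhibition at all stays open.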